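The compounds below may be only part of what the source reports. "The series", "measured", "known", "first", "only" and "open" are said of these compounds alone.

Series notes. Three analogues of a shared core have been measured in a functional assay on KB cells (Homo sapiens) for cytotoxicity, read by sulforhodamine B assay, with a stated time of 3 days; a lower number here means that less compound is needed, a higher number that more compound is needed for the effect. Compound 1 `CCOc1c(-c2occ(C)c2CO)ccc2c1CCCC2(C)C` gives 16.9 uM. Compound 2 `Cc1coc(-c2ccc3c(c2O)CCCC3(C)C)c1CO` gives 22 uM, and compound 3 `CCOCc1c(C)coc1-c1ccc2c(c1OC)CCCC2(C)C` gives 21.6 uM. All three values sit within the usual scatter of one another; the value of compound 3 lies nearest that of compound 2 and furthest from that of compound 1, yet neither gap is beyond the scatter, so no ordering among the three can be read from these numbers.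

Compound 4 `COc1c(-c2occ(C)c2CO)ccc2c1CCCC2(C)C` is the next analogue and has not yet been measured in this assay. Relative to compound 3 it carries hydrogen in place of ethyl on an oxygen on a saturated carbon. Within the data shown here, the one measured step that bears on this is the removal of the same ethyl from an oxygen, though there on an aromatic ring rather than on a saturated carbon: a 1.3-fold higher number from compound 1 to compound 2 (0.11 log units; within the scatter). That step stayed within the scatter, and nothing else in the set addresses an ethyl-to-hydrogen exchange on an oxygen on a saturated carbon. For compound 4 the expected step is therefore a 1.0-fold higher number from compound 3 to compound 4 (0.01 log units; within the scatter), none beyond the scatter in either direction. Compound 4 is estimated at 22 uM, with a range from 10 uM to 48 uM.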

Compound 4, concentration for half-maximal effect: 25.3 uM
Compound 4: the middle estimate sits 1.2-fold (0.06 log units) below what was measured; the measured number falls inside the stated range.
By their numbers in this assay, from the lowest: compounds 1, 3, 2 and 4 (each within the scatter of the next).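

At the oxygen on a saturated carbon, the change from ethoxymethyl to hydroxymethyl now has a direct reading in this assay: a 1.2-fold higher number from compound 3 to compound 4 (0.07 log units; within the scatter), so hydrogen in place of ethyl stays within the scatter here as well as on the oxygen on an aromatic ring. The oxygen on an aromatic ring also gains two readings with the hydroxymethyl group held constant: methyl in place of hydrogen gives a 1.2-fold higher number from compound 2 to compound 4 (0.06 log units; within the scatter), and hydrogen in place of methyl on the saturated chain carbon bound to that oxygen gives a 1.5-fold higher number from compound 1 to compound 4 (0.18 log units; within the scatter), which puts the hydroxy form compound 2, the methoxy form compound 4 and the ethoxy form compound 1 within the scatter of one another. No supporting data accompany these results to account for them.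

From the compounds shown here alone, the oxygen on a saturated carbon is read only with hydrogen and ethyl, and only alongside the methoxy group on the aromatic ring, so the same exchange alongside hydroxy or ethoxy remains open. Going by these compounds, whether a longer chain or a chain ending in an amine at either oxygen would give a step beyond the scatter also remains open.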